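The compounds below may be only part of what the source reports. "The series", "measured", "known", "first", "only" and "open" are said of these compounds alone.

In a functional assay on MCF7 cells (Homo sapiens) for antiproliferative activity, read by fluorescence and SYBR Green assay, with a stated time of 24 h (on this read-out higher numbers stand for weaker inhibition and lower numbers for stronger inhibition), the measured compounds are these.
Compound 1 `CN1CCN(S(=O)(=O)c2ccc(N3CCCC3=O)cc2)c2ccccc21` gives 10 nM.
Compound 2 `Cc1ccc2c(c1)CCCN2S(=O)(=O)c1ccc(N2CCCC2=O)cc1` gives 15 nM.
Compound 3 `O=S(=O)(c1ccc(-n2cncn2)cc1)N1CCCc2ccccc21` gives only > 5000 nM, which is a limit of the assay and not a number.

Compound 2 and compound 1 sit so close together that their numbers fall within the usual scatter of repeated measurements; the two cannot be told apart. Compound 3 stands apart, because the limit of > 5000 nM in this assay, at which 1 of the 3 values shown sits, is reached and nothing more is known of it.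

Compound 4 `CC(C)(C)c1ccc2c(c1)CCCN2S(=O)(=O)c1ccc(N2CCCC2=O)cc1` has not yet been measured. It differs from compound 2 in one place: tert-butyl in place of methyl on an aromatic carbon. Among the measured compounds shown here, no measured pair in this set shows what such a swap does here, so the expected size of the step rests on compound 2 alone. A small move in this assay is expected, toward weaker inhibition if anything, but not far beyond the scatter. The estimated step from compound 2 to compound 4 is a 2.0-fold higher number from compound 2 to compound 4 (0.30 log units; within the scatter). Compound 4 is therefore expected to give about 30 nM, within a range from 8 nM to 150 nM.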

Compound 4, half-maximal inhibitory concentration: 318 nM
Beside the measured number, compound 4's estimate is 11-fold (1.03 log units) below it, outside the stated range (above it).
By their numbers in this assay, from the lowest: compounds 1 and 2 (each within the scatter of the next); then compound 4. At a limit, above all of these: compound 3.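

Inhibition in this assay depends strongly on the group at this aromatic carbon, which is meta to a fused ring and para to a fused ring: tert-butyl in place of methyl gives a 21-fold higher number from compound 2 to compound 4 (1.33 log units; beyond the scatter) in a change that adds only carbon and no ring, donor, acceptor or charge. Compound 4 still gives a measured number, 318 nM, so inhibition is weakened but not lost. No measurement shown here explains the size of this step.

With only methyl and tert-butyl shown at this carbon, it remains open whether ethyl or isopropyl would behave more like methyl or more like tert-butyl, and how a group with other atoms, such as an amine or methoxy, would fare there. Going by these compounds, whether the same swap would have a similar effect on a different core also remains open.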